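This account rests on a few compounds, and the source may have more. Where it says the series, first, only, none or still open, it means among the compounds named here.

Compound 3 `Cc1ccc(C(=O)N/N=C/c2cc(Br)ccc2O)c(O)c1` gives 1090 nM in a functional assay (Mus musculus, strain BALB/C) for inhibition, read by MTT assay, with stated times of 24 h and 72 h; on this read-out lower numbers stand for stronger inhibition and higher numbers for weaker inhibition; compound 1 `COc1cccc(/C=N/NC(=O)c2ccc(C)cc2O)c1` gives 20600 nM; compound 2 `Cc1ccc(C(=O)N/N=C/c2cccc(F)c2)c(O)c1` gives 31200 nM.

Compound 3 stands lowest of the three numbers in this assay, with compound 1 nearest and compound 2 furthest, both gaps beyond the scatter. Compound 4 `Cc1ccc(C(=O)N/N=C/c2cccc(Br)c2)c(O)c1` differs from compound 3 by hydrogen in place of hydroxy on an aromatic carbon, at a place ortho to a large group and para to a bromo group. Among the compounds with values here, the only measured step, a 1.5-fold higher number from compound 1 to compound 2 (0.18 log units; within the scatter), exchanges one substituent for another and lies within the scatter; no step removes a hydroxy. Compound 4 is nevertheless expected to weaken markedly, because compound 1 gives 20600 nM and compound 2 gives 31200 nM while also lacking that hydroxy. This weakening is expected to amount to a 14-fold higher number from compound 3 to compound 4 (1.14 log units; beyond the scatter). Compound 4 is estimated at 15000 nM, within 4000 nM to 50000 nM.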

Compound 4, half-maximal inhibitory concentration: 28300 nM
Estimate against measurement, compound 4: 1.9-fold (0.28 log units) below; the measured number falls inside the stated range.
By their numbers in this assay, from the lowest: compound 3; then compounds 1, 4 and 2 (each within the scatter of the next).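

Hydrogen in place of hydroxy, at the place ortho to a large group and para to a bromo group, gives a 26-fold higher number from compound 3 to compound 4 (1.41 log units; beyond the scatter) in this assay and is the first step here to lie beyond the scatter. Without that hydroxy the other substituent changes little, as a 1.1-fold lower number from compound 2 to compound 4 (0.04 log units; within the scatter) and a 1.4-fold higher number from compound 1 to compound 4 (0.14 log units; within the scatter) show for bromo in place of fluoro and of methoxy.

As far as these compounds go, whether an amine or a carboxylic acid at this place could stand in for the hydroxy stays open, as does the part the bromo group plays while the hydroxy is present. Nothing measured here explains the size of this loss.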